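Compound 2 to compound 3: 2,4-dichlorophenyl replaces 4-bromophenyl

A few compounds are considered here, and "the series" means these few. Any claim that something is new, unique, unknown or untested is made for them only; others in the source may bear on it.

Among the measured compounds shown here, in a functional assay on DU-145 cells (Homo sapiens) for inhibition (on this read-out higher numbers stand for weaker inhibition of growth and lower numbers for stronger inhibition of growth), compound 2 (`O=S(=O)(/C=C/c1ccc(Br)cc1)Cc1ccc(Nc2ncnc3ccccc23)cc1`) gives 55000 nM as the highest of the two numbers so far, while compound 1 (`O=S(=O)(/C=C/c1ccccc1)Cc1ccc(Nc2ncnc3ccccc23)cc1`) gives 2000 nM as the lower one. Compound 3 (`O=S(=O)(/C=C/c1ccc(Cl)cc1Cl)Cc1ccc(Nc2ncnc3ccccc23)cc1`) carries 2,4-dichlorophenyl in place of 4-bromophenyl on a double-bonded chain carbon bound to a double-bonded chain carbon. For the measured compounds named here, the one measured step bearing on this change is a 28-fold higher number from compound 1 to compound 2 (1.44 log units; beyond the scatter) for bromo in place of hydrogen on an aromatic carbon, and it is large. Going by the values given here, no measured compound carries chlorine, so this step is only a loose guide. A moderate move toward stronger inhibition of growth is expected, and the estimated step is a 3.7-fold lower number from compound 2 to compound 3 (0.56 log units; beyond the scatter) with wide uncertainty. Compound 3 is estimated at 15000 nM in this assay with an expected range from 2500 nM to 70000 nM for this read-out.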

Compound 3, concentration for 50% growth inhibition: 3000 nM
Estimate against measurement, compound 3: 5.0-fold (0.70 log units) above; the range from low to high includes it.
By their numbers in this assay, from the lowest: compounds 1 and 3 (each within the scatter of the next); then compound 2.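

The change to 2,4-dichlorophenyl in this assay gives an 18-fold lower number from compound 2 to compound 3 (1.26 log units; beyond the scatter) and so takes back, at this place on a double-bonded chain carbon bound to a double-bonded chain carbon, what 4-bromophenyl lost in a 28-fold higher number from compound 1 to compound 2 (1.44 log units; beyond the scatter) on the way from the unsubstituted phenyl. Against phenyl itself, 2,4-dichlorophenyl gives a 1.5-fold higher number from compound 1 to compound 3 (0.18 log units; within the scatter) and this shows that halogen on this ring does not always go with weaker inhibition of growth, with compound 2 as the one case against. Nothing on hand accounts for the gap between the two halogenated groups.

The halogen and its number change together from compound 2 to compound 3, so the compounds shown do not separate the two effects. On these data alone, how a single chlorine in place of the bromine, or a methoxy group or an amine on this ring, would read remains open.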